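Benzyl sulfide variants of compound 2: cytotoxicity on gastric cells

The source may hold more compounds than are shown below. What is called first, only, known or untested is meant among the compounds shown, and "the series" means these compounds.

Measured so far:
- compound 1 `C[C@@H]1CCN(c2cc(-c3ccccc3)nc3ncnn23)C[C@@H]1N(C)c1ncnc2[nH]ccc12`: > 100000 nM
- compound 2 `Cc1cc(N2CC[C@@H](C)[C@@H](N(C)c3ncnc4[nH]ccc34)C2)n2nc(SCc3nc4ccccc4[nH]3)nc2n1`: 40200 nM
- compound 3 `COc1ccc(CSc2nc3nc(C)cc(N4CC[C@@H](C)[C@@H](N(C)c5ncnc6[nH]ccc56)C4)n3n2)cc1`: > 100000 nM

For the measured compounds named here, in a toxicity assay on GES1 cells (Homo sapiens) for inhibition, read by MTT assay, with a stated time of 72 h (on this read-out higher numbers stand for weaker inhibition and lower numbers for stronger inhibition), compound 2 gives 40200 nM and is the only compound with a number rather than a limit. For compound 1 the value > 100000 nM is a limit of this assay. For compound 3 the value > 100000 nM is likewise a limit. Two of the three values therefore sit at the limit of > 100000 nM in this assay, at which 2 of the 3 values shown sit.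

Compound 4 `Cc1ccc(CSc2nc3nc(C)cc(N4CC[C@@H](C)[C@@H](N(C)c5ncnc6[nH]ccc56)C4)n3n2)cc1` is not yet measured. It differs from compound 2 as follows: 4-methylphenyl in place of 1H-benzimidazol-2-yl on a saturated chain carbon bound to a sulfur

Going by the values given here, the one measured step that bears on this change is an at least 2.4-fold higher number from compound 2 to compound 3 (0.39 log units; beyond the scatter), in which the same sulfur-bound chain carbon also lost its 1H-benzimidazol-2-yl for a phenyl bearing a single substituent. Compound 4 carries 4-methylphenyl in that place, a close relative of the 4-methoxyphenyl of compound 3, so a step of similar size in the same direction is expected, that is toward weaker inhibition and quite possibly again a limit. Compound 4 is expected to give about 100000 nM in this assay, with a range from 40000 nM to 250000 nM. The expected step is a 2.5-fold higher number from compound 2 to compound 4 (0.40 log units; beyond the scatter).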

Compound 4, half-maximal inhibitory concentration: 82500 nM
Beside the measured number, compound 4's estimate is 1.2-fold (0.08 log units) above it; low and high end bracket the measured number.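

In this assay, the change on a saturated chain carbon bound to a sulfur now has a number at both ends: a 2.1-fold higher number from compound 2 to compound 4 (0.31 log units; beyond the scatter). Compound 3 gives > 100000 nM, which is a limit and not a number. Against that limit the reading is an at least 1.2-fold lower number from compound 3 to compound 4 (0.08 log units; that floor lies within the scatter), so no order is established for methyl in place of methoxy on an aromatic carbon.

On these data alone, how far the compounds at the top of the range lie past it stays open: the limit of > 100000 nM in this assay, at which 2 of the 4 values shown sit. Also open is whether a benzyl group carrying an amine or a carboxylic acid in that place would read closer to compound 2 or to compound 4.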